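Substituent on the aromatic nitrogen of the shared core

The compounds below may be only part of what the source reports. "The series", "measured", "known", "first", "only" and "open" are said of these compounds alone.

Measured so far:
compound 1 `CC(C)c1onc(-c2c(Cl)cccc2Cl)c1COc1ccc(-c2nc3ccc(C(=O)O)cc3n2C(C)C)cc1` — 3.39 nM
compound 2 `CC(=O)N1CCC(n2c(-c3ccc(OCc4c(-c5c(Cl)cccc5Cl)noc4C(C)C)cc3)nc3ccc(C(=O)O)cc32)CC1` — 1430 nM
compound 3 `CC(C)c1onc(-c2c(Cl)cccc2Cl)c1COc1ccc(-c2nc3ccc(C(=O)O)cc3n2C2CCCCCC2)cc1` — 14.8 nM

In an assay on Huh-7 cells for agonist activity at Bile acid receptor (Homo sapiens), read by a luciferase reporter (a lower number here means that less compound is needed, a higher number that more compound is needed for the effect), compound 1 gives 3.39 nM, the lowest of the three numbers; compound 3 is nearest to it and compound 2 furthest. Both measured steps leave the rest of the core untouched and change only the group on the aromatic nitrogen. Replacing isopropyl by cycloheptyl gives a 4.4-fold higher number from compound 1 to compound 3 (0.64 log units; beyond the scatter); replacing it by 1-acetylpiperidin-4-yl gives a 420-fold higher number from compound 1 to compound 2 (2.63 log units; beyond the scatter). Compound 4 `CC(=O)C1CCC(Cn2c(-c3ccc(OCc4c(-c5c(Cl)cccc5Cl)noc4C(C)C)cc3)nc3ccc(C(=O)O)cc32)CC1` differs from compound 1 by (4-acetylcyclohexyl)methyl in place of isopropyl on an aromatic nitrogen. Both earlier departures from isopropyl raised the number, and the entering group here combines a saturated six-membered carbon ring, as in cycloheptyl, with an acetyl carbonyl, as in the acetylpiperidinyl group of compound 2, though attached through an extra carbon and without the ring nitrogen. A rise beyond the scatter is therefore expected, lying between the two measured steps. The expected step is an 18-fold higher number from compound 1 to compound 4 (1.25 log units; beyond the scatter). Compound 4 is estimated at 60 nM, within 12 nM to 300 nM.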

Compound 4, half-maximal effective concentration: 1170 nM
Estimate against measurement, compound 4: 20-fold (1.29 log units) below; measured number above the stated range.
By their numbers in this assay, from the lowest: compound 1; then compound 3; then compounds 4 and 2 (each within the scatter of the next).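

Notes on the group on the aromatic nitrogen, read in this assay: (4-acetylcyclohexyl)methyl gives a 350-fold higher number from compound 1 to compound 4 (2.54 log units; beyond the scatter) as its step from isopropyl, and a 1.2-fold lower number from compound 2 to compound 4 (0.09 log units; within the scatter) places it level with 1-acetylpiperidin-4-yl, so a loss of this size does not need a nitrogen in the ring. A saturated carbon ring alone does not bring this loss either, as a 79-fold higher number from compound 3 to compound 4 (1.90 log units; beyond the scatter) separates the new group from cycloheptyl. Among these four compounds the large rises go with the two groups carrying an acetyl carbonyl, none going against this, but no measurement here bears on the reason for these steps.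

On these data alone, it remains open whether a plain cyclohexylmethyl group would stay close to cycloheptyl or rise as far as the acetyl-bearing groups. Also open, as far as these compounds go, is how a hydroxyl or an amine in place of the acetyl, or a smaller group such as ethyl or cyclopropyl in place of isopropyl, would read.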